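Swapping the ketone ring of compound 3 for phenyl

The source may hold more compounds than are shown below. What is called first, only, known or untested is meant among the compounds shown, and "the series" means these compounds.

Compound 3 `O=C(/C=C/c1cn(-c2ccccc2)nc1-c1ccncc1)c1ccsc1` gives 1100 nM in a functional assay on HCT-116 cells (Homo sapiens) for inhibition, read by sulforhodamine B assay, with a stated time of 72 h (a lower number here means a stronger inhibitor, a higher number a weaker inhibitor), the lowest of the three numbers shown, though the step of a 1.2-fold lower number from compound 2 to compound 3 (0.07 log units; within the scatter) from compound 2 `O=C(/C=C/c1cn(-c2ccccc2)nc1-c1cccnc1)c1ccsc1`, which gives 1300 nM, sits within the scatter; compound 1 `O=C(/C=C/c1cn(-c2ccccc2)nc1-c1ccsc1)c1ccccc1` gives 5100 nM, a clearly higher number. Compound 4 `O=C(/C=C/c1cn(-c2ccccc2)nc1-c1ccncc1)c1ccccc1` differs from compound 3 by phenyl in place of thiophen-3-yl on a carbonyl carbon. Going by the values given here, no measured pair isolates this change: compound 1 also carries a benzoyl group but differs from compound 3 in two places, so its higher number cannot be traced to the ketone ring alone. Among the compounds with values here, with no step bearing directly on the change, a step of a 1.4-fold higher number from compound 3 to compound 4 (0.13 log units; within the scatter) is expected, within the scatter. Compound 4 is therefore estimated at 1500 nM in this assay, between 600 nM and 4500 nM.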

Compound 4, half-maximal inhibitory concentration: 3100 nM
The estimate for compound 4 lay 2.1-fold (0.32 log units) below the measured number; the range from low to high includes it.
By their numbers in this assay, from the lowest: compounds 3 and 2 (each within the scatter of the next); then compounds 4 and 1 (each within the scatter of the next).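

In this assay, the ketone ring now has a measured pair of its own: phenyl in place of thiophen-3-yl on a carbonyl carbon gives a 2.8-fold higher number from compound 3 to compound 4 (0.45 log units; beyond the scatter), a modest step beyond the scatter. The other change reaching compound 4 gives a 1.6-fold lower number from compound 1 to compound 4 (0.22 log units; within the scatter), which stays within the scatter. Nothing measured here explains the step at the ketone ring. The compounds shown leave open how a cyclohexyl group or a furan-2-yl ring would read on that carbonyl carbon. They also leave open whether the ketone ring step holds with pyridin-3-yl on the core.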